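A few compounds are considered here, and "the series" means these few. Any claim that something is new, unique, unknown or untested is made for them only; others in the source may bear on it.

Compound 1 `O/N=C(/Nc1cccc(F)c1)c1ccc2occc2c1` gives in an assay on tissue (HeLa cells) for inhibition of Indoleamine 2,3-dioxygenase 1 (Homo sapiens), read by spectrophotometry (on this read-out higher numbers stand for weaker inhibition and lower numbers for stronger inhibition), a value of 20000 nM. Compound 2 `O/N=C(/Nc1cccc(COc2ccccc2)c1)c1ccc2occc2c1` reaches only a limit of this assay, > 30000 nM. Within the data shown here, the one measured step, an at least 1.5-fold higher number from compound 1 to compound 2 (0.17 log units; that floor lies within the scatter), is thus known only as a floor; the pair sits at the limit of > 30000 nM in this assay, at which 1 of the 2 values shown sits. Compound 3 `O/N=C(/Nc1cccc(-c2ccccc2)c1)c1ccc2occc2c1` differs from compound 2 by phenyl in place of phenoxymethyl on an aromatic carbon. This change is not covered by the measured step, which concerns a different pair of groups and gives no direction for a phenyl in place of phenoxymethyl. Among the measured compounds shown here, the only anchor is that compound 2 stands at a limit of this assay, while compound 1, its nearest measured neighbour, gives a number close to that limit. On that basis no step beyond the scatter is expected, and compound 3 is estimated to give 30000 nM in this assay, within 8000 nM to 100000 nM. The expected step of a number no higher from compound 2 to compound 3 (the limit leaves the size open) is accordingly small, with a fair chance that only a limit is reported.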

Compound 3, half-maximal inhibitory concentration: 11900 nM
Compound 3: middle estimate off by 2.5-fold (0.40 log units), on the high side; low and high end bracket the measured number.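

In this assay, phenyl in place of phenoxymethyl on this aromatic carbon gives an at least 2.5-fold lower number from compound 2 to compound 3 (0.40 log units; beyond the scatter), so the position can carry a six-membered aromatic ring of carbon only and still return a measured number. The size of that step remains a floor, as the value for compound 2 is a limit and not a number: the limit of > 30000 nM in this assay, at which 1 of the 3 values shown sits. Phenyl in place of fluoro gives a 1.7-fold lower number from compound 1 to compound 3 (0.23 log units; within the scatter), so this pair does not separate the two groups on this read-out.

The compounds shown leave open whether the oxygen or the chain length within phenoxymethyl accounts for the step to phenyl, which a benzyl group at the same carbon could test. From the compounds shown here alone, how an amine or a carboxylic acid on the phenyl of compound 3 would shift the number also remains open.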